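This account rests on a few compounds, and the source may have more. Where it says the series, first, only, none or still open, it means among the compounds named here.

Of the compounds shown here, three built on a shared core have been measured in a functional assay on K562 cells (Homo sapiens) for inhibition, read by MTT assay, with a stated time of 72 h; on this read-out lower numbers stand for stronger inhibition and higher numbers for weaker inhibition. Compound 1 `Cc1ccc(-n2cc(CCO)nn2)cc1Nc1nccc(-c2cccnc2)n1` carries a triazole bearing a hydroxyethyl chain, and in this assay compound 1 gives 10700 nM. Compound 2 `Cc1ccc(-c2nnc(-c3ccc(C)c(C(F)(F)F)c3)o2)cc1Nc1nccc(-c2cccnc2)n1` instead carries an oxadiazole with a 4-methyl-3-(trifluoromethyl)phenyl group, and in this assay compound 2 reaches only the limit > 30000 nM. Compound 3 `Cc1ccc(-c2nnc(-c3cccnc3)o2)cc1Nc1nccc(-c2cccnc2)n1` keeps that oxadiazole but with pyridin-3-yl on it, and in this assay compound 3 likewise reaches only the limit > 30000 nM. The step that the two limits leave unreadable from compound 2 to compound 3 therefore cannot be read, because both values sit at the limit of > 30000 nM in this assay, at which 2 of the 3 values shown sit. Compound 3 thus stands at the limit, not at a number. Going by the values given here, compound 1 is the only compound here with a measured value.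

Compound 4 `Cc1nnc(-c2ccc(C)c(Nc3nccc(-c4cccnc4)n3)c2)o1` has not been measured. It differs from compound 3 by methyl in place of pyridin-3-yl on an aromatic carbon. No readable measured step bears on this change. With compound 3 at the limit, compound 4 is expected to give 30000 nM, within a range from 8000 nM to 100000 nM, most likely again as a limit rather than a number. The step of a number no higher from compound 3 to compound 4 (the limit leaves the size open) is accordingly expected to be one that cannot be told apart from the scatter.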

Compound 4, half-maximal inhibitory concentration: > 30000 nM
Compound 4: no number, only a limit; the forecaster's own chance of this, stated with the estimate: 65%; the middle value lies on the limit itself.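

In this assay compound 4 gives > 30000 nM as a limit and not a number, so methyl at this place on the ring, with no ring of its own, gives no readable value, just as the two larger aromatic groups gave none. The steps among compound 2, compound 3 and compound 4 cannot be read, and all three stand together at the limit: the limit of > 30000 nM in this assay, at which 3 of the 4 values shown sit. Against the triazole bearing the hydroxyethyl chain, the change to 5-methyl-1,3,4-oxadiazol-2-yl gives an at least 2.8-fold higher number from compound 1 to compound 4 (0.44 log units; beyond the scatter) and this is the first step in the series of readable size.

On these data alone, it remains open whether the triazole or its hydroxyethyl chain accounts for that step, since the two change together. As far as these compounds go, an amine or a carboxylic acid on the oxadiazole, or a methyl on the triazole, would speak to what is still unknown.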